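The source may hold more compounds than are shown below. What is called first, only, known or untested is meant among the compounds shown, and "the series" means these compounds.

Compound 3 `Fc1cccc(F)c1Cc1cnc(Nc2ccc(Oc3ccncc3)c(Cl)c2)o1` gives 21000 nM in an ADME assay on MT2 cells (Homo sapiens) for cytotoxicity, read by MTT assay (a lower number here means that less compound is tolerated, a higher number that more compound is tolerated), the second highest of the three numbers recorded: compound 1 `Fc1cccc(F)c1Cc1cnc(Nc2ccc(Oc3cccnc3)c(Cl)c2)o1` gives 16000 nM, within the scatter of it, while compound 2 `Clc1cccc(Cl)c1Cc1nnc(Nc2ccc(COCc3cccnc3)cc2)o1` gives 81000 nM, beyond it. Compound 4 `[O-][n+]1ccc(OCc2ccc(Nc3ncc(Cc4c(F)cccc4F)o3)cc2Cl)cc1` is not yet measured and differs from compound 3 by a group of 9 heavy atoms (6 carbon, 1 nitrogen, 2 oxygen; one six-membered aromatic ring with 1 hetero atom) in place of a group of 7 heavy atoms (5 carbon, 1 nitrogen, 1 oxygen; one six-membered aromatic ring with 1 hetero atom), on an aromatic carbon. For the measured compounds named here, the only single-change step measured is a 1.3-fold higher number from compound 1 to compound 3 (0.12 log units; within the scatter), which exchanged one pyridinyl for another and stayed within the scatter; no measured step replaces (pyridin-4-yl)oxy with a group of the kind entering here. Compound 2 carries a different group in that place, but its core differs too, so its value offers no clean comparison. Compound 4 is therefore expected to show a step of a 1.2-fold higher number from compound 3 to compound 4 (0.08 log units; within the scatter), which need not exceed the scatter, estimated at 25000 nM within 10000 nM to 60000 nM.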

Compound 4, half-maximal cytotoxic concentration: 1700 nM
For compound 4 the middle estimate is 15-fold (1.17 log units) above the measured one, and the stated range ends above it.
By their numbers in this assay, from the lowest: compound 4; then compounds 1 and 3 (each within the scatter of the next); then compound 2.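

In this assay, this aromatic carbon had shown no change beyond the scatter when one pyridinyl replaced another, yet replacing the whole group there gives a 12-fold lower number from compound 3 to compound 4 (1.09 log units; beyond the scatter) and a 9.4-fold lower number from compound 1 to compound 4 (0.97 log units; beyond the scatter). The position is therefore sensitive to the group it carries, and less compound is tolerated with the group of 9 heavy atoms. No measurement here bears on why the number falls. On these data alone, the added carbon and oxygen enter together, so their separate shares remain open. As far as these compounds go, whether a methoxy group or an amine on this carbon would also lower the number remains open too.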